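The source may report more compounds than this note shows. Statements on the series, on what has been measured and on what is new or still open speak of the compounds shown alone.

Three compounds that differ in one place on a shared core have been measured in an ADME assay on microsomes from liver (Rattus norvegicus) for metabolic stability, with a stated time of 60 min, tested at 1 uM; on this read-out higher numbers stand for a more stable compound and lower numbers for a less stable compound. Compound 1 `CNc1nc2c(-c3ccnc(OC)c3)cnn2cc1OC`, which carries methylamino, gives 74%. Compound 2 `COc1cc(-c2cnn3cc(OC)c(C(C)(C)O)nc23)ccn1`, which carries 1-hydroxy-1-methylethyl, gives 92%. Compound 3 `COc1cc(-c2cnn3cc(OC)c(C)nc23)ccn1`, which carries methyl, gives 13%, the lowest of the three numbers and well clear of the scatter from both others.

Compound 4 `COc1cc(-c2cnn3cc(OC)c([C@@H]4COC(C)(C)C4)nc23)ccn1` changes that same group of compound 3: a group of 7 heavy atoms (6 carbon, 1 oxygen; one five-membered non-aromatic ring with 1 hetero atom) in place of one carbon atom, on an aromatic carbon. A group with one five-membered non-aromatic ring thus takes the place of methyl, on an aromatic carbon.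

Going by the values given here, two measured steps bear on this change, and both end at methyl: a number 61 percentage points lower from compound 1 to compound 3 (beyond the scatter), and a number 79 percentage points lower from compound 2 to compound 3 (beyond the scatter). Both are large, so in these three compounds methyl is the group with the lowest number. Leaving it is therefore expected to bring a clear rise in this assay. Among the compounds with values here, none of the measured groups contains a ring, however, so these steps guide the direction better than the size, and the range must stay wide. The expected step is a number 39 percentage points higher from compound 3 to compound 4 (beyond the scatter). For compound 4 the estimate is 52%, with an expected range of 22% to 82%.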

Compound 4, percent of the compound remaining: 30%
Estimate against measurement, compound 4: 22 percentage points above, and the stated range covers the measured number.
By their numbers in this assay, from the lowest: compound 3; then compound 4; then compound 1; then compound 2.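

In this assay, replacing methyl with the group bearing a five-membered non-aromatic ring gives a number 17 percentage points higher from compound 3 to compound 4 (beyond the scatter), so a ring with one hetero atom can sit on this aromatic carbon and still raise the number, though only modestly. The same ring group falls far short of the two smaller open groups, with a number 44 percentage points lower from compound 1 to compound 4 (beyond the scatter) and a number 62 percentage points lower from compound 2 to compound 4 (beyond the scatter), so among these four compounds the order does not follow group size: methyl, the smallest group, has the lowest number, but the largest group comes next, below both methylamino and 1-hydroxy-1-methylethyl. No measurement here explains why these groups fall in this order, and the numbers alone describe the pattern without accounting for it.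

The compounds shown leave open how much of the result depends on the ring oxygen or the two extra methyl groups, which a plain cyclopentyl group or an unsubstituted tetrahydrofuranyl group would help separate. They also leave open whether the opposite arrangement at the defined stereocentre, or an open-chain ether such as 1-methoxy-1-methylethyl, would give a different number in this assay.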